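Phenoxy to Carbamoyl: a Single Change Before Testing

A few compounds are considered here, and "the series" means these few. Any claim that something is new, unique, unknown or untested is made for them only; others in the source may bear on it.

Two compounds have been run in an ADME assay on cells (Macrophage, Mus musculus) for cytotoxicity, read by resazurin assay, with a stated time of 3 days; a higher number here means a weaker inhibitor, a lower number a stronger inhibitor. Compound 1 `O=C(Nc1cc(C(F)(F)F)cc(C(F)(F)F)c1)c1cccc(Cl)c1` reaches only a limit of the assay, and in this assay compound 1 gives > 60000 nM. Within the data shown here, compound 2 `O=C(Nc1ccc(Oc2ccccc2)cc1)c1cc(Cl)ccc1O` is the only one with a proper number: in this assay compound 2 gives 43000 nM. Among the measured compounds shown here, the other value is a limit, so compound 2 can be set only against (the limit of > 60000 nM in this assay, at which 1 of the 2 values shown sits), and no step between two measured compounds can be described. Compound 3 `NC(=O)c1ccc(NC(=O)c2cc(Cl)ccc2O)cc1` is not yet measured. It differs from compound 2 in one place: carbamoyl in place of phenoxy on an aromatic carbon. For the measured compounds named here, with no comparable measured step to lean on, the expectation is a change no larger than the scatter, if anything towards a weaker inhibitor, with a real chance that only a limit is reported. Compound 3 is therefore estimated at 55000 nM, within a range of 25000 nM to 120000 nM. The step expected by that estimate is a 1.3-fold higher number from compound 2 to compound 3 (0.11 log units; within the scatter).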

Compound 3, half-maximal inhibitory concentration: > 60000 nM
Compound 3 ended at the assay's limit (the forecaster's own chance of this, stated with the estimate: 45%); middle value at least 1.0-fold (0.03 log units) away from the limit.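

In this assay, the phenoxy ring on this aromatic carbon, para to a large group, can give way to carbamoyl, which has no ring, without the number moving lower: the change gives an at least 1.3-fold higher number from compound 2 to compound 3 (0.14 log units; that floor lies within the scatter). From the compounds shown here alone, compound 3 gives > 60000 nM, which is a limit of the assay and not a number, so this step is only a floor and its true size stays unknown. Most of the compounds shown now end at the same point: the limit of > 60000 nM in this assay, at which 2 of the 3 values shown sit.

The compounds shown leave open whether an amine, a carboxylic acid or a nitrile on this carbon would give a proper number in this assay rather than a limit. Among these compounds, with only one proper number so far, it also stays open how far any group at this position can move the read-out.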